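Swapping an Imidazole Tail for a Piperidine Tail

The compounds below may be only part of what the source reports. "The series", "measured", "known", "first", "only" and "open" are said of these compounds alone.

Compound 1 is `Cn1cc(C2=C(c3nn(CCn4ccnc4)c4ncccc34)C(=O)NC2=O)c2ccccc21`. In a functional assay on SMMC-7721 cells (Homo sapiens) for antiproliferative activity, read by MTT assay, with a stated time of 48 h (a lower number here means a stronger inhibitor, a higher number a weaker inhibitor), compound 1 gives only a limit, > 100000 nM, so no number is known for it. Compound 2 is `Cn1cc(C2=C(c3nn(CCCN4CCCCC4)c4ncccc34)C(=O)N(c3ccccn3)C2=O)c2ccccc21`, and in this assay compound 2 likewise reaches only a limit, > 100000 nM. Among the compounds with values here, compound 3 is `Cn1cc(C2=C(c3nn(CCCn4ccnc4)c4ncccc34)C(=O)N(c3ccccc3)C2=O)c2ccccc21`; in this assay compound 3 gives 34800 nM, the one number among the three. Compound 1 thus stands at the limit of > 100000 nM in this assay, at which 2 of the 3 values shown sit.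

Compound 4 is `Cn1cc(C2=C(c3nn(CCCN4CCCCC4)c4ncccc34)C(=O)NC2=O)c2ccccc21` and has not yet been measured. It differs from compound 1 in one place: (piperidin-1-yl)methyl in place of 1H-imidazol-1-yl on a saturated chain carbon, two bonds along the chain from an aromatic nitrogen.

Within the data shown here, no two measured compounds differ in only one place, so no measured step guides the expectation. Compound 2 carries the same chain as compound 4 and sits at a limit, which gives little ground for expecting a gain. The expected step is an at least 1.1-fold lower number from compound 1 to compound 4 (0.04 log units; that floor lies within the scatter), nothing beyond the usual scatter. In this assay compound 4 is expected to give about 90000 nM, within 30000 nM to 300000 nM, with a fair chance that only a limit is again reported.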

Compound 4, half-maximal inhibitory concentration: 7670 nM
Beside the measured number, compound 4's estimate is 12-fold (1.07 log units) above it, and the stated range ends above it.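

In this assay, the group at the end of the chain clearly matters: (piperidin-1-yl)methyl in place of 1H-imidazol-1-yl gives an at least 13-fold lower number from compound 1 to compound 4 (1.11 log units; beyond the scatter). With the 3-(piperidin-1-yl)propyl chain held fixed, the amide-type nitrogen in a ring matters too: hydrogen in place of pyridin-2-yl gives an at least 13-fold lower number from compound 2 to compound 4 (1.11 log units; beyond the scatter). Each step starts from a limit rather than a number, so its full size stays unknown: the limit of > 100000 nM in this assay, at which 2 of the 4 values shown sit.

On these data alone, the first change swaps the ring and lengthens the chain together, so it remains open which of the two carries the gain, and a 2-(piperidin-1-yl)ethyl tail on the same core would separate them. A morpholine ring or an open-chain dimethylamino group at the chain end would show how far the piperidine ring itself is needed.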